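Biaryl acid replacements in the benzazepinone series

A few compounds are considered here, and "the series" means these few. Any claim that something is new, unique, unknown or untested is made for them only; others in the source may bear on it.

compound 1, `CC(C)(N)CC(=O)N[C@@H]1CCc2ccccc2N(Cc2ccc(-c3ccccc3C(=O)O)cc2)C1=O`, in a functional assay (Pituitary gland cell) with Rattus norvegicus as the target; a lower number here means that less compound is needed, a higher number that more compound is needed for the effect: 3 uM
compound 2, `CC(C)(N)CC(=O)N[C@@H]1CCc2ccccc2N(Cc2ccc(-c3ccccc3-c3nnn(Cc4ccccc4)n3)cc2)C1=O`, in this assay: 1 uM

For the measured compounds named here, compound 2 holds the lowest of the two numbers so far; its only neighbour is compound 1, and the single measured step, a 3.0-fold lower number from compound 1 to compound 2 (0.48 log units; beyond the scatter), is modest but beyond the scatter. Compound 3, `CC(C)(N)CC(=O)N[C@@H]1CCc2ccccc2N(Cc2ccc(-c3ccccc3S(N)(=O)=O)cc2)C1=O`, is the next member: sulfamoyl in place of 2-benzyl-2H-tetrazol-5-yl on an aromatic carbon. Going by the values given here, only that one step bears on it, and it bears loosely, since it shows that swapping the carboxy for a larger group moved the number modestly downward, not what a small group with one hydrogen-bond donor will do. The expectation is that compound 3 gives up part of what compound 2 gained, so the step from compound 2 to compound 3 is expected to be an upward one, a 3.0-fold higher number from compound 2 to compound 3 (0.48 log units; beyond the scatter). Compound 3 is therefore estimated at 3 uM in this assay, with a range from 1 uM to 10 uM.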

Compound 3, concentration for half-maximal effect: 3 uM
For compound 3 middle estimate and measured number coincide at the digits printed; the range from low to high includes it.
By their numbers in this assay, from the lowest: compound 2; then compounds 1 and 3 (each within the scatter of the next).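

Sulfamoyl in place of 2-benzyl-2H-tetrazol-5-yl gives a 3.0-fold higher number from compound 2 to compound 3 (0.48 log units; beyond the scatter), while sulfamoyl in place of carboxy gives no change at the digits printed from compound 1 to compound 3 (within the scatter). At this aromatic carbon, ortho to a large group, carboxy and sulfamoyl therefore cannot be told apart in this assay, and of the three groups only 2-benzyl-2H-tetrazol-5-yl stands apart from the others. Nothing at hand accounts for this difference.

Open, going by these compounds, is whether the step belongs to the tetrazole ring or to its benzyl group, which an unsubstituted tetrazol-5-yl or a 2-methyl-2H-tetrazol-5-yl at the same carbon would separate. Also open, on these data alone, is whether a methylsulfonyl or an acetylsulfamoyl group there would stay with carboxy and sulfamoyl or move toward 2-benzyl-2H-tetrazol-5-yl.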